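The source may hold more compounds than are shown below. What is called first, only, known or untested is meant among the compounds shown, and "the series" means these compounds.

In a functional assay on HeLa cells (Homo sapiens) for antiproliferative activity, read by MTT assay, with a stated time of 48 h (a lower number here means a stronger inhibitor, a higher number a weaker inhibitor), compound 1 (`COc1cc(C(=O)/C=C/c2c[nH]c3ccccc23)cc(SC)c1OC`) gives 159 nM and compound 2 (`COc1ccc2c(/C=C/C(=O)c3cc(OC)c(OC)c(SC)c3)cn(C)c2c1`) gives 167 nM so these two values lie within the usual scatter of each other. Compound 3 (`COc1cc(C(=O)/C=C/c2cn(C)c3ccccc23)cc(SC)c1OC`) has not yet been measured and differs from compound 2 by having hydrogen in place of methoxy on an aromatic carbon. For the measured compounds named here, no measured pair tests this change, so no step beyond the scatter is expected in this assay in either direction. The expected change is a 1.2-fold lower number from compound 2 to compound 3 (0.08 log units; within the scatter) and would stay within the scatter. Compound 3 is estimated at 140 nM with an expected range from 50 nM to 400 nM for a single measurement.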

Compound 3, half-maximal inhibitory concentration: 105 nM
Estimate against measurement, compound 3: 1.3-fold (0.12 log units) above; the range from low to high includes it.
By their numbers in this assay, from the lowest: compounds 3, 1 and 2 (each within the scatter of the next).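

Hydrogen in place of methoxy on an aromatic carbon now has a direct test: in this assay the step is a 1.6-fold lower number from compound 2 to compound 3 (0.20 log units; within the scatter) and stays within the scatter. Methyl in place of hydrogen on an aromatic nitrogen gives a 1.5-fold lower number from compound 1 to compound 3 (0.18 log units; within the scatter) and also stays within the scatter, so neither single change separates these compounds. No measurement on hand offers an explanation for these results. Still open, as far as these compounds go, is whether an ethyl or benzyl group on that nitrogen, or an amine or fluorine in place of the methoxy, would give a step beyond the scatter.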